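A few compounds are considered here, and "the series" means these few. Any claim that something is new, unique, unknown or untested is made for them only; others in the source may bear on it.

Compound 1 `CC1(C)CC(=O)c2c(-c3ccc(F)cc3)cc(-c3ccccc3)nc2C1` was tested in an assay on isolated protein for inhibition of glucose-6-phosphatase catalytic subunit 1 (Homo sapiens), read by inositol phosphate accumulation, with a stated time of 30 min, tested at 100 uM (on this read-out higher numbers stand for more inhibition at the one concentration tested (going by the name of the read-out) and lower numbers for less inhibition), and gives 11.1%. Compound 3 `CC1(C)CC(=O)C2=C(C1)NC(c1ccccc1)=CC2c1ccc(F)cc1` carries the same 4-fluorophenyl group on a different core; the difference between the two cores is not broken down here. In this assay compound 3 gives 7.38%, and compound 2 `CC1(C)CC(=O)C2=C(C1)NC(c1ccccc1)=CC2c1ccc(Cl)cc1` gives 7.16%. Compound 1 differs from compound 3 and from compound 2 by amounts within the usual scatter of such measurements, so the three cannot be told apart on this read-out. The change from compound 3 to compound 2 is chloro in place of fluoro on an aromatic carbon, and it made a step of a number 0.2 percentage points lower from compound 3 to compound 2 (within the scatter). Compound 4 `CC1(C)CC(=O)c2c(-c3ccc(Cl)cc3)cc(-c3ccccc3)nc2C1` has not yet been measured; it differs from compound 1 by chloro in place of fluoro on an aromatic carbon, the same change at the same place. Because the earlier step of a number 0.2 percentage points lower from compound 3 to compound 2 (within the scatter) lay within the scatter, a similarly small step is expected in this assay, namely a number 0.1 percentage points lower from compound 1 to compound 4 (within the scatter). Compound 4 is therefore estimated to give 11% in this assay, most likely between 2% and 20%.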

Compound 4, a percentage reported as inhibition, at one concentration (the size of the read-out at that concentration, not a potency): 11.3%
For compound 4 the middle estimate is 0.3 percentage points below the measured one, within the range that was stated.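

In this assay, putting chloro in place of fluoro on the core of compound 1 made a step of a number 0.2 percentage points higher from compound 1 to compound 4 (within the scatter). Set beside the same change on the other core, this step does not differ from the earlier one: the same change on two cores in this assay, a number 0.2 percentage points lower (within the scatter) from compound 3 to compound 2 and a number 0.2 percentage points higher (within the scatter) from compound 1 to compound 4, 0.4 percentage points apart, within the scatter of two such steps. The swap from 4-fluorophenyl to 4-chlorophenyl therefore made no measurable difference on either core, but this does not show that the two cores would respond alike to a change that moved the number, and readings at one concentration say nothing about potency.

The compounds shown vary that position only between fluoro and chloro, leaving open what an amine, a carboxylic acid or a methoxy group there would give in this assay. They also leave open whether a longer chain in place of the unsubstituted phenyl group or of the two methyl groups on the core would change the read-out at all.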